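Substituent changes on the aromatic nitrogen

The source may hold more compounds than are shown below. What is called first, only, known or untested is meant among the compounds shown, and "the series" means these compounds.

Compound 1 `COc1ccc([C@@H]2CC(=O)c3c(O)cc(OCc4cn(Cc5ccc(C(F)(F)F)cc5)nn4)cc3O2)cc1O` gives 17700 nM in a functional assay on RAW264.7 cells (Mus musculus) for inhibition, read by Griess assay, with stated times of 2 h and 24 h; on this read-out lower numbers stand for stronger inhibition and higher numbers for weaker inhibition; compound 2 `COc1ccc([C@@H]2CC(=O)c3c(O)cc(OCc4cn(C5CCCC5)nn4)cc3O2)cc1O` gives 10500 nM, and compound 3 `CCCCn1cc(COc2cc(O)c3c(c2)O[C@H](c2ccc(OC)c(O)c2)CC3=O)nn1` gives 13900 nM. Compound 3 thus stands second highest of the three numbers, with compound 1 nearest and compound 2 furthest, all three within the scatter of one another. Compound 4 `COc1ccc([C@@H]2CC(=O)c3c(O)cc(OCc4cn(Cc5ccc(F)cc5)nn4)cc3O2)cc1O` is compound 3 with 4-fluorophenyl in place of propyl on a saturated chain carbon bound to an aromatic nitrogen. The step that bears on this change runs the other way, a 1.3-fold lower number from compound 1 to compound 3 (0.10 log units; within the scatter), and neither a 1.7-fold lower number from compound 1 to compound 2 (0.23 log units; within the scatter) nor a 1.3-fold higher number from compound 2 to compound 3 (0.12 log units; within the scatter) moves beyond the scatter either. With a 4-fluorophenyl entering, a step of no clear direction is expected for compound 4, a 1.1-fold higher number from compound 3 to compound 4 (0.03 log units; within the scatter). Compound 4 is expected at 15000 nM, with a range from 7000 nM to 32000 nM.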

Compound 4, half-maximal inhibitory concentration: 15100 nM
The estimate for compound 4 lay 1.0-fold (0.00 log units) below the measured number; low and high end bracket the measured number.
By their numbers in this assay, from the lowest: compounds 2, 3, 4 and 1 (each within the scatter of the next).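

In this assay, 4-fluorophenyl in place of propyl on a saturated chain carbon bound to an aromatic nitrogen (a 1.1-fold higher number from compound 3 to compound 4 (0.04 log units; within the scatter)) stays within the scatter, so at this place an aromatic ring reads the same as a chain. The comparison with cyclopentyl on the aromatic nitrogen (a 1.4-fold higher number from compound 2 to compound 4 (0.16 log units; within the scatter)) and fluoro in place of trifluoromethyl on an aromatic carbon (a 1.2-fold lower number from compound 1 to compound 4 (0.07 log units; within the scatter)) also stay within the scatter. No evidence bears on why these numbers stay so close.

Open, going by these compounds, is whether an amine, a carboxylic acid or a longer chain such as octyl on the aromatic nitrogen would move the number beyond the scatter.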